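The source may hold more compounds than are shown below. What is called first, only, known or untested is meant among the compounds shown, and "the series" means these compounds.

Three thiourea compounds built on the same core have been measured in an ADME assay on MT4 cells (Homo sapiens) for cytotoxicity; a lower number here means that less compound is tolerated, a higher number that more compound is tolerated. Compound 1 `FC(F)(F)c1cccc(NC(=S)Nc2ccc(Cl)cc2)c1` gives 6800 nM. Compound 2 `Fc1ccc(NC(=S)Nc2cccc(C(F)(F)F)c2)cc1` gives 31000 nM, so that a 4.6-fold higher number from compound 1 to compound 2 (0.66 log units; beyond the scatter). Compound 3 `FC(F)(F)c1cccc(NC(=S)NCc2ccco2)c1` gives 43000 nM, the highest of the three numbers, although its gap to compound 2 lies within the scatter, since a 1.4-fold higher number from compound 2 to compound 3 (0.14 log units; within the scatter); only its gap to compound 1 is clear, because a 6.3-fold higher number from compound 1 to compound 3 (0.80 log units; beyond the scatter).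

Compound 4 `CSCCCNC(=S)Nc1cccc(C(F)(F)F)c1` differs from compound 3 in one place: 2-(methylsulfanyl)ethyl in place of furan-2-yl on a saturated chain carbon bound to an amide-type nitrogen. The two steps that bear on this are the ones leading into compound 3, in which the group on the amide-type nitrogen was exchanged; one was modest, the other within the scatter. Neither step replaced an aromatic ring with an open chain, so the direction is uncertain, and no step beyond the scatter is expected in this assay.

Compound 4 is therefore estimated at 40000 nM, with a range from 15000 nM to 100000 nM, and the expected step is a 1.1-fold lower number from compound 3 to compound 4 (0.03 log units; within the scatter).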

Compound 4, half-maximal cytotoxic concentration: 43000 nM
Beside the measured number, compound 4's estimate is 1.1-fold (0.03 log units) below it; low and high end bracket the measured number.
By their numbers in this assay, from the lowest: compound 1; then compounds 2, 3 and 4 (each within the scatter of the next).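

In this assay the step shows no change at the digits printed from compound 3 to compound 4 (within the scatter) when the aromatic furan-2-yl ring gives way to the open 2-(methylsulfanyl)ethyl chain, so a ring at this place, on a saturated chain carbon bound to an amide-type nitrogen, is not needed for the number seen with compound 3. The chain also leaves the earlier picture in place: the comparison with the 4-fluorophenyl compound gives a 1.4-fold higher number from compound 2 to compound 4 (0.14 log units; within the scatter) and the comparison with the 4-chlorophenyl compound gives a 6.3-fold higher number from compound 1 to compound 4 (0.80 log units; beyond the scatter) and so, of the four, only compound 1 stands apart. Nothing measured here accounts for these numbers.

Still open, as far as these compounds go, is whether the sulfur of the chain matters, which a plain butyl chain would test. From the compounds shown here alone, it is equally open whether a longer chain, or an amine or a carboxylic acid at the end of the chain, would keep the number at this level.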